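Fluoro to methoxycarbonyl: working notes on the series

The compounds below may be only part of what the source reports. "The series", "measured", "known", "first", "only" and "open" are said of these compounds alone.

Values measured so far in a physicochemical assay for lipophilicity (a higher number here means a more lipophilic compound, a lower number a more polar compound), are these:
- compound 1 `O=C(CC1CCC2(CC1)OOCCCOO2)N1CCOCC1` gives 1.16
- compound 2 `Fc1ccc(CC2CCC3(CC2)OOCCCOO3)cc1` gives 4.01

Compound 2 stands the higher of the two, by a gap beyond the scatter. Compound 3 `COC(=O)c1ccc(CC2CCC3(CC2)OOCCCOO3)cc1` has methoxycarbonyl in place of fluoro on an aromatic carbon, para to a large group (methoxycarbonyl in place of fluoro on an aromatic carbon). Among the compounds with values here, no measured pair shows this change, so the expectation rests on the structural change alone. A small downward move in this assay is expected, with a number 0.16 log units lower from compound 2 to compound 3 (within the scatter) as the estimated step, and it may not exceed the scatter. Compound 3 is estimated at 3.85 with an expected range from 3.4 to 4.3 on the same scale.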

Compound 3, partition coefficient: 3.75
Compound 3: the middle estimate sits 0.10 log units above what was measured, and the stated range covers the measured number.
By their numbers in this assay, from the lowest: compound 1; then compounds 3 and 2 (each within the scatter of the next).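

In this assay, methoxycarbonyl in place of fluoro on an aromatic carbon, para to a large group, gives a number 0.26 log units lower from compound 2 to compound 3 (within the scatter). Within the data shown here, this is the first reading of any change at this position, and a larger group carrying hydrogen-bond acceptors leaves the number within the scatter of the fluoro compound. No measurement at hand explains this outcome.

On these data alone, whether an amine or a carboxylic acid on the same aromatic carbon would also stay this close to compound 2 remains open, as does the outcome for an ester with a longer chain.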